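Dimethylamino on the saturated ring of compound 1

The compounds below may be only part of what the source reports. "The series", "measured", "known", "first", "only" and "open" are said of these compounds alone.

Compound 1, `NS(=O)(=O)OC[C@@H]1C[C@@H](n2nnc3c(N[C@H]4CCc5ccccc54)ncnc32)C[C@@H]1O`, gives 0.21 nM in an assay on a protein complex for inhibition of NEDD8 activating enzyme (Homo sapiens), read by HTRF, with a stated time of 2 h, in the presence of a further agent that is not named here (on this read-out higher numbers stand for weaker inhibition and lower numbers for stronger inhibition), and so holds the lowest number of the two measured in this assay. For the measured compounds named here, the only other measured compound, compound 2, `NS(=O)(=O)OC[C@@H]1C[C@@H](n2nnc3c(NCc4cccs4)ncnc32)C[C@@H]1O`, gives 15.9 nM; the step between them, a 76-fold higher number from compound 1 to compound 2 (1.88 log units; beyond the scatter), follows an exchange of the whole group on the aromatic nitrogen. Compound 3, `CN(C)[C@H]1Cc2ccccc2[C@H]1Nc1ncnc2c1nnn2[C@@H]1C[C@@H](COS(N)(=O)=O)[C@@H](O)C1`, keeps that group and differs from compound 1 only by dimethylamino in place of hydrogen on a saturated ring carbon. Going by the values given here, no measured step touches a substituent on that saturated ring; the one step that exists swaps the ring out entirely, so it does not bear on this change. A step of some size is therefore expected, but its direction is not read from the data. Since compound 1 already stands at 0.21 nM, an estimate that allows for a modest loss is taken, with wide bounds, so that compound 3 is expected to give 1 nM (range 0.15 nM to 8 nM) in this assay. That estimate means an expected step of a 4.8-fold higher number from compound 1 to compound 3 (0.68 log units; beyond the scatter).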

Compound 3, half-maximal inhibitory concentration: 207 nM
Compound 3: the middle estimate sits 210-fold (2.32 log units) below what was measured; the whole stated range lies below it.
By their numbers in this assay, from the lowest: compound 1; then compound 2; then compound 3.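

In this assay, the saturated ring carbon next to the ring atom that bears a large group proves highly sensitive to substitution: dimethylamino in place of hydrogen gives a 990-fold higher number from compound 1 to compound 3 (2.99 log units; beyond the scatter). The earlier step exchanged the whole group on the aromatic nitrogen, whereas this one keeps the fused ring system of compound 1 and changes a single ring carbon, so the large loss of inhibition does not require removing that ring system. Nothing available explains the size of this step.

Going by these compounds, it remains open whether the loss belongs to dimethylamino specifically or would follow any group on this carbon; methyl, hydroxyl, methoxy or a primary amine in the same place would help to separate these cases. The opposite spatial arrangement of dimethylamino on this carbon is also an open question, as the present result describes only the arrangement in compound 3, and it cannot yet be said whether this ring carbon tolerates any substituent at all.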